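A few compounds are considered here, and "the series" means these few. Any claim that something is new, unique, unknown or untested is made for them only; others in the source may bear on it.

Compounds measured in a functional assay (ileum) for inhibition, with Cavia porcellus as the target; a lower number here means that less compound is needed, a higher number that more compound is needed for the effect:
- compound 1 `CC(C)NC1=NS(=O)(=O)c2cccnc2N1`: a limit, > 300 uM
- compound 2 `CC(NC1=NS(=O)(=O)c2cccnc2N1)C(C)(C)C`: a limit, > 300 uM
- compound 3 `O=S1(=O)N=C(NCC2CCCCC2)Nc2ncccc21`: 145 uM

Going by the values given here, compound 3 stands alone: in this assay it is the only compound with a number, the other two results being limits (the limit of > 300 uM in this assay, at which 2 of the 3 values shown sit). Compound 4 `C[C@H](NC1=NS(=O)(=O)c2cccnc2N1)C1CCCCC1` differs from compound 3 by one change, (methyl in place of hydrogen on a saturated chain carbon bound to an amine nitrogen and a saturated ring carbon). Among the compounds with values here, the only measured step that resembles this change is the one from compound 1 to compound 2, which is a step that the two limits leave unreadable from compound 1 to compound 2; it therefore gives no size to lean on. What the three values do show is that compound 1 and compound 2, each carrying a branched saturated carbon bound to the amine nitrogen, sit at the limit, whereas compound 3, with an unbranched carbon there, gives a number. Adding a methyl at the carbon bound to the amine nitrogen in compound 4 moves it toward the branched pattern of compound 1 and compound 2, so a loss beyond the scatter in this assay is expected, and there is a real chance that only a limit will be reported. Compound 4 is estimated at 300 uM, with a range from 100 uM to 1000 uM, which means an expected step of a 2.1-fold higher number from compound 3 to compound 4 (0.32 log units; beyond the scatter) from compound 3.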

Compound 4, concentration for half-maximal effect: > 300 uM
Compound 4 ended at the assay's limit; the forecaster's own chance of this, stated with the estimate: 50%; the middle value lies on the limit itself.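

In this assay, methyl in place of hydrogen on a saturated chain carbon bound to an amine nitrogen and a saturated ring carbon gives an at least 2.0-fold higher number from compound 3 to compound 4 (0.31 log units; beyond the scatter), the only readable step among the compounds shown, as the step between the two limits of compound 1 and compound 2 cannot be read. Compound 4 gives > 300 uM, which is a limit. This single methyl is thus enough to carry the one compound with a number to a result beyond the scatter, and with no exception among the compounds shown, each one with a branched carbon bound to the amine nitrogen now sits at the same limit: the limit of > 300 uM in this assay, at which 3 of the 4 values shown sit.

The compounds shown leave open how large the step from the hydrogen to the methyl really is, since only its lower bound can be read, and whether the mirror-image form of compound 4 behaves the same way at this carbon. They also leave open whether an ethyl, a hydroxymethyl or a longer chain in place of that methyl would give a number in this assay or stay at the limit.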